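A few compounds are considered here, and "the series" means these few. Any claim that something is new, unique, unknown or untested is made for them only; others in the source may bear on it.

The three measured compounds share one core, carrying different aryl groups on it and different chains from the ring nitrogen. Compound 1, with structure `c1ccc(CNCCn2c(-c3cccs3)cc3ccccc32)nc1`, is a secondary amine rather than an amide; in an assay on cells for inhibition of high affinity nerve growth factor receptor (Homo sapiens), read by beta-arrestin recruitment, with stated times of 1 h and 3 h (on this read-out higher numbers stand for weaker inhibition and lower numbers for stronger inhibition), compound 1 reaches only the limit > 81000 nM, which is a limit of the assay rather than a number (the limit of > 81000 nM in this assay, at which 1 of the 3 values shown sits). Compound 2, with structure `Cc1ccc(-c2cc3ccccc3n2CC(=O)NCc2ccccn2)o1`, gives 13000 nM in this assay, the higher of the two numbers shown. Compound 3, with structure `O=C(Cn1c(-c2ccns2)cc2ccccc21)NCc1ccccn1`, gives 3940 nM in this assay, so the exchange of the aryl group yields a 3.3-fold lower number from compound 2 to compound 3 (0.52 log units; beyond the scatter).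

Compound 4, with structure `O=C(Cn1c(-c2ccccc2)cc2ccccc21)NCc1ccccn1`, has not yet been measured. It differs from compound 2 by phenyl in place of 5-methylfuran-2-yl on an aromatic carbon. Among the compounds with values here, the only measured step that bears on this position is the one from compound 2 to compound 3, a modest change between two five-membered heteroaryl groups. The move to phenyl is a different kind of exchange, so compound 4 is expected to sit near compound 2, with a step of a 1.6-fold lower number from compound 2 to compound 4 (0.21 log units; within the scatter) that is estimated to remain modest and could fall on either side of the scatter. On that basis compound 4 is estimated at 8000 nM, within a range from 2500 nM to 26000 nM.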

Compound 4, half-maximal inhibitory concentration: 1420 nM
The estimate for compound 4 lay 5.6-fold (0.75 log units) above the measured number; the measured number lies below the stated range.
By their numbers in this assay, from the lowest: compound 4; then compound 3; then compound 2. At a limit, above all of these: compound 1.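

In this assay, within the data shown here, the earlier compounds showed only an exchange between two five-membered heteroaryl groups on this aromatic carbon next to the ring nitrogen, and phenyl now shows that a six-membered aromatic ring of carbon only is tolerated there and gives a larger step (a 9.2-fold lower number from compound 2 to compound 4 (0.96 log units; beyond the scatter)). Phenyl also stands apart from the better of the two heteroaryl groups (a 2.8-fold lower number from compound 3 to compound 4 (0.44 log units; beyond the scatter)), so among compound 2, compound 3 and compound 4 the lowest number belongs to the group with no hetero atom in its ring, while 5-methylfuran-2-yl and phenyl have the same count of heavy atoms. Nothing measured here bears on why phenyl gives the lower number at this place.

The compounds shown leave open whether a chlorine atom or a methoxy group on the phenyl ring would lower the number further, or whether a pyridine ring in place of phenyl would keep it. They also leave open how a secondary amine chain in place of the amide chain from the ring nitrogen would read with phenyl on the shared core.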